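Benzyl ester in place of methyl ester on the amine side chain

A few compounds are considered here, and "the series" means these few. Any claim that something is new, unique, unknown or untested is made for them only; others in the source may bear on it.

Three compounds sharing one core have been checked in a functional assay on HEL cells (Homo sapiens) for cytotoxicity, read by microscopy; a lower number here means that less compound is tolerated, a higher number that more compound is tolerated. Compound 1 `CCOC(=O)NC(=O)NC1=CS(=O)(=O)O[C@@]12[C@@H](CO[Si](C)(C)C(C)(C)C)O[C@@H](n1cc(C)c(=O)n(C)c1=O)[C@@H]2O[Si](C)(C)C(C)(C)C` gives 16000 nM. Compound 2 `COC(=O)C(=O)CNC1=CS(=O)(=O)O[C@@]12[C@@H](CO[Si](C)(C)C(C)(C)C)O[C@@H](n1cc(C)c(=O)n(C)c1=O)[C@@H]2O[Si](C)(C)C(C)(C)C` reaches only a limit of the measurement, > 400000 nM. Compound 3 `COC(=O)CNC1=CS(=O)(=O)O[C@@]12[C@@H](CO[Si](C)(C)C(C)(C)C)O[C@@H](n1cc(C)c(=O)n(C)c1=O)[C@@H]2O[Si](C)(C)C(C)(C)C` likewise gives a limit rather than a number, >= 400000 nM; it sits at the limit of >= 400000 nM in this assay, at which 1 of the 3 values shown sits, so within these three it stands at the high, well-tolerated end. The two readable steps, an at least 25-fold higher number from compound 1 to compound 2 (1.39 log units; beyond the scatter) and an at least 25-fold higher number from compound 1 to compound 3 (1.39 log units; beyond the scatter), both swap the whole group on the amine nitrogen, and the step that the two limits leave unreadable from compound 2 to compound 3 cannot be sized. Compound 4 `Cc1cn([C@@H]2O[C@H](CO[Si](C)(C)C(C)(C)C)[C@@]3(OS(=O)(=O)C=C3NCC(=O)OCc3ccccc3)[C@H]2O[Si](C)(C)C(C)(C)C)c(=O)n(C)c1=O` differs from compound 3 by phenyl in place of hydrogen on a saturated chain carbon bound to an oxygen next to a carbonyl group. Among the measured compounds shown here, none of the measured steps touches this ester carbon, so no change beyond the scatter is expected, and the step from compound 3 to compound 4 is estimated at an at least 1.3-fold lower number from compound 3 to compound 4 (0.12 log units; that floor lies within the scatter). Compound 4 is therefore expected to give about 300000 nM, within 60000 nM to 400000 nM, most likely again as a limit.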

Compound 4, minimum cytotoxic concentration: >= 400000 nM
Compound 4 ended at the assay's limit; the forecaster's own chance of this, stated with the estimate: 60%; middle value at least 1.3-fold (0.12 log units) away from the limit.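

In this assay compound 4 gives >= 400000 nM, which is a limit of the assay and not a number. A phenyl on this saturated chain carbon bound to an oxygen next to a carbonyl group therefore leaves the compound at the assay's limit, the well-tolerated end of the series: the limit of >= 400000 nM in this assay, at which 2 of the 4 values shown sit. Replacing (ethoxycarbonyl)carbamoyl on the amine nitrogen with (benzyloxycarbonyl)methyl gives an at least 25-fold higher number from compound 1 to compound 4 (1.39 log units; beyond the scatter), while the steps to compound 4 from compound 2 and compound 3 cannot be read, as both ends of each are limits.

From the compounds shown here alone, how far the methyl and benzyl esters truly differ therefore stays unknown. Going by these compounds, it is also open whether a free carboxylic acid or a simple amide on this side chain would stay at the limit or give a readable number.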